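Methylsulfanyl for methylsulfonyl on two fluoro-positioned cores

The source may hold more compounds than are shown below. What is called first, only, known or untested is meant among the compounds shown, and "the series" means these compounds.

Measured so far:
compound 1 `CS(=O)(=O)c1ccc(F)cc1NCC1=NCCN1` — 96%
compound 2 `CS(=O)(=O)c1cc(F)ccc1NCC1=NCCN1` — 61%
compound 3 `CSc1ccc(F)cc1NCC1=NCCN1` — 90%

In a functional assay for agonist activity at Alpha-1A adrenergic receptor (Homo sapiens) (a lower number here means a smaller maximal response, a higher number a larger maximal response), compound 1 gives 96% and compound 3 gives 90%. The change between them is methylsulfanyl in place of methylsulfonyl on an aromatic carbon, and the step it made is a number 6 percentage points lower from compound 1 to compound 3 (within the scatter).

Compound 2 gives 61% in this assay, the lowest of the three numbers, beyond the scatter from both compound 3 and compound 1. The difference between the core of compound 2 and the core of compound 1 is not broken down here.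

Compound 4 `CSc1cc(F)ccc1NCC1=NCCN1` is not yet measured. It differs from compound 2 by methylsulfanyl in place of methylsulfonyl on an aromatic carbon. Among the compounds with values here, this is the same kind of change as the one from compound 1 to compound 3, but the place differs: in compound 1 the site is para to a fluoro group, in compound 2 it is meta to a fluoro group.

For compound 4 the expected value in this assay is 57%, with a range of 40% to 75%. The step this estimate means is a number 4 percentage points lower from compound 2 to compound 4 (within the scatter), expected to be small because a number 6 percentage points lower from compound 1 to compound 3 (within the scatter) was within the scatter.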

Compound 4, largest response reached (reported as maximum), in percent of the reference or control that the assay uses: 93%
Beside the measured number, compound 4's estimate is 36 percentage points below it, outside the stated range (above it).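

In this assay, methylsulfanyl in place of methylsulfonyl on an aromatic carbon gives a number 32 percentage points higher from compound 2 to compound 4 (beyond the scatter), and this step does not match the one seen for the same change on the other core: the same change on two cores in this assay, a number 6 percentage points lower (within the scatter) from compound 1 to compound 3 and a number 32 percentage points higher (beyond the scatter) from compound 2 to compound 4, 38 percentage points apart, beyond the scatter of two such steps

The change therefore does not carry over between these two cores as a fixed step, and its size in this series depends on the core that bears it. These two pairs do not show why the steps differ, nor whether either step would hold on a further core or in a different assay.

The compounds shown carry only methylsulfonyl or methylsulfanyl at this place, so it remains open how a methoxy group, an amine or a longer thioether chain would behave there on either core. As far as these compounds go, it also remains open whether the core dependence would persist if the fluoro group were replaced by chlorine or by a methyl group.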